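Series notes: swapping the benzylic aryl on the shared core

A few compounds are considered here, and "the series" means these few. Any claim that something is new, unique, unknown or untested is made for them only; others in the source may bear on it.

Compound 2 `Nc1nc(O)c2c(n1)n(C1OC(CO)[C@@H](O)[C@H]1O)c(=O)n2Cc1ccc(Cl)cc1` holds the second highest of the three numbers in a functional assay (B cells) with Mus musculus as the target (on this read-out lower numbers stand for an effect already at smaller amounts and higher numbers for an effect only at larger amounts of compound), giving 14 uM. Compound 3 `Nc1nc(O)c2c(n1)n(C1OC(CO)[C@@H](O)[C@H]1O)c(=O)n2Cc1ccc(OCc2ccccc2)cc1` gives 8 uM in this assay, and compound 1 `CCOC(=O)Cn1c(=O)n(C2OC(CO)[C@@H](O)[C@H]2O)c2nc(N)nc(O)c21` gives 48 uM. The step of a 1.8-fold lower number from compound 2 to compound 3 (0.24 log units; within the scatter) lies within the scatter, whereas a 3.4-fold lower number from compound 1 to compound 2 (0.54 log units; beyond the scatter) lies beyond it. Compound 4 `NCC(O)Cn1c(=O)n(C2OC(CO)[C@@H](O)[C@H]2O)c2nc(N)nc(O)c21` differs from compound 2 by 2-amino-1-hydroxyethyl in place of 4-chlorophenyl on a saturated chain carbon bound to an aromatic nitrogen. The step of a 3.4-fold lower number from compound 1 to compound 2 (0.54 log units; beyond the scatter) bears on this change most directly: compound 1 likewise carries no ring at this place, and its number is the highest of the three. The reverse of that step is therefore expected, namely a 3.6-fold higher number from compound 2 to compound 4 (0.55 log units; beyond the scatter). The estimate for compound 4 in this assay is 50 uM, with a range from 18 uM to 150 uM.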

Compound 4, concentration for half-maximal effect: 28 uM
The estimate for compound 4 lay 1.8-fold (0.25 log units) above the measured number; the range from low to high includes it.
By their numbers in this assay, from the lowest: compounds 3, 2, 4 and 1 (each within the scatter of the next, the first and the last beyond it).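

In this assay, the step of a 2.0-fold higher number from compound 2 to compound 4 (0.30 log units; within the scatter) lies within the scatter, and so does the step of a 1.7-fold lower number from compound 1 to compound 4 (0.23 log units; within the scatter) in the same assay. 3-Amino-2-hydroxypropyl therefore cannot be told apart from either 4-chlorobenzyl or the ethoxycarbonyl-bearing chain, although compound 1 and compound 2 do separate, so the lack of a ring at this place does not by itself fix the number. No evidence is available to explain this result. Still open, going by these compounds, is whether a plain aminoethyl chain or a carboxylic acid in place of the ethoxycarbonyl would separate from compound 2.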